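Phenyl for benzyl on a saturated ring carbon

The source may report more compounds than this note shows. Statements on the series, on what has been measured and on what is new or still open speak of the compounds shown alone.

For the measured compounds named here, in a functional assay on MCF7 cells (Homo sapiens) for inhibition, read by MTT assay, with a stated time of 48 h, tested at 10 uM (on this read-out higher numbers stand for more inhibition of growth at the one concentration tested and lower numbers for less inhibition of growth), compound 1 (`Cc1cc(=O)c2c(O)c(CN3CCC(N4CCCCC4)CC3)c(O)c([C@H]3CCN(C)C[C@H]3O)c2o1`) gives 25% and stands as the only comparison available. Compound 2 (`Cc1cc(=O)c2c(O)c(CN3CCC(Cc4ccccc4)CC3)c(O)c([C@H]3CCN(C)C[C@H]3O)c2o1`) gives 17% there, within the scatter of compound 1. Compound 3 (`Cc1cc(=O)c2c(O)c(CN3CCC(c4ccccc4)CC3)c(O)c([C@H]3CCN(C)C[C@H]3O)c2o1`) has not yet been measured and carries phenyl in place of benzyl on a saturated ring carbon. Going by the values given here, the one measured step on that ring carbon is a number 8 percentage points lower from compound 1 to compound 2 (within the scatter) and it stays within the scatter, though it exchanges benzyl for a different group and no measured step involves phenyl. Among the compounds with values here, with only that step to go on, no change beyond the scatter is expected in this assay here. The expected change is a number 3 percentage points higher from compound 2 to compound 3 (within the scatter) and its direction is not meaningful. For compound 3 the estimate is 20% with an expected range from 8% to 35% on this measure.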

Compound 3, percent growth inhibition at one concentration: 23%
Compound 3: middle estimate off by 3 percentage points, on the low side, and the stated range covers the measured number.
By their numbers in this assay, from the lowest: compounds 2, 3 and 1 (each within the scatter of the next).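

In this assay, shortening benzyl to phenyl on this saturated ring carbon gives a number 6 percentage points higher from compound 2 to compound 3 (within the scatter) and so adds a second group comparison at the same position, while phenyl in place of piperidin-1-yl gives a number 2 percentage points lower from compound 1 to compound 3 (within the scatter) and thus links the aromatic and the saturated ring substituents directly. Piperidin-1-yl, benzyl and phenyl therefore all stay within the scatter of one another here, so this position shows no separation among these groups at the one concentration tested. Nothing at hand explains this flat picture.

On these data alone, it remains open whether a longer chain such as 2-phenylethyl, a primary amine or a carboxylic acid on this ring carbon would move the number beyond the scatter. The compounds shown also leave open how these three would compare across a range of concentrations.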